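Swapping chloro for methyl on a weak thiosemicarbazone

The source may report more compounds than this note shows. Statements on the series, on what has been measured and on what is new or still open speak of the compounds shown alone.

Measured so far:
- compound 1, `S=C(N/N=C/c1ccc2ccccc2n1)Nc1cccc(Cl)c1`: 48100 nM
- compound 2, `CN(C)C(=S)N/N=C/c1ccc2cccnc2n1`: 410 nM
- compound 3, `CN(C)C(=S)N/N=C/c1ccc2ccccc2n1`: 20 nM

All three were tested in a functional assay on HT-29 cells (Homo sapiens) for antiproliferative activity, read by sulforhodamine B assay, with a stated time of 72 h; a lower number here means a stronger inhibitor, a higher number a weaker inhibitor. Compound 1 stands at the high end of these three numbers: compound 2 gives 410 nM and compound 3 gives 20 nM, both well beyond the scatter of repeated measurements from compound 1, so compound 1 is clearly the weakest of the three. Compounds 2 and 3 differ from compound 1 in more than one place, so no single step among the measured compounds explains the gap.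

The next compound, compound 4, `Cc1cccc(NC(=S)N/N=C/c2ccc3ccccc3n2)c1`, keeps the core of compound 1 and changes one group: methyl in place of chloro on an aromatic carbon. Within the data shown here, nothing measured so far shows what such an exchange does in this assay. Since chloro and methyl are both single heavy atoms without donors or acceptors, the step is expected to be small, in either direction, and most likely within the scatter; the expected step from compound 1 to compound 4 is a 1.2-fold lower number from compound 1 to compound 4 (0.08 log units; within the scatter). Compound 4 is therefore estimated to give 40000 nM, within a range of 12000 nM to 130000 nM.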

Compound 4, half-maximal inhibitory concentration: > 100000 nM
Compound 4 gave a limit, no number; the forecaster's own chance of this, stated with the estimate: 10%; at least 2.5-fold (0.39 log units) between middle value and limit.
By their numbers in this assay, from the lowest: compound 3; then compound 2; then compound 1. At a limit, above all of these: compound 4.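

In this assay, the change from 3-chlorophenyl to 3-methylphenyl is not a neutral exchange, as it gives an at least 2.0-fold higher number from compound 1 to compound 4 (0.31 log units; beyond the scatter) and so moves the reading beyond the scatter. Chloro and methyl each count as one heavy atom, with no ring, no hydrogen-bond donors and no hydrogen-bond acceptors, so these counts alone do not predict how this position responds to a change. From the compounds shown here alone, the value for compound 4 is a limit of the assay and not a number, so the step gives only a lower bound on the size of the change, and its true size stays unknown: the limit of > 100000 nM in this assay, at which 1 of the 4 values shown sits.

Still open, going by these compounds, is whether an amine or a carboxylic acid in this same place on the phenyl ring would give a measurable number, and whether that number would fall below the value of compound 1. This single pair also cannot show whether the same exchange of chloro for methyl would have a similar effect in any other pair of compounds.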